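Extending the pentyl substituent of compound 2

The compounds below may be only part of what the source reports. "The series", "measured", "known", "first", "only" and "open" are said of these compounds alone.

For the measured compounds named here, compound 2 `CCCCCN1CCC(NC(=O)c2cc(Cl)c(N)cc2OC)CC1` holds the lowest of the two numbers so far in an assay on HEK293 cells for displacement of a labelled ligand from 5-hydroxytryptamine receptor 4 (Homo sapiens), read by scintillation counting (a lower number here means a stronger inhibitor, a higher number a weaker inhibitor), where compound 2 gives 100 nM. Going by the values given here, its nearest neighbour is compound 1 `COc1cc(N)c(Cl)cc1C(=O)NC1CCNCC1`, which in this assay gives 1580 nM; the single step between them, a 16-fold lower number from compound 1 to compound 2 (1.20 log units; beyond the scatter), came with pentyl in place of hydrogen on an amine nitrogen in a ring.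

Compound 3 `COc1cc(N)c(Cl)cc1C(=O)NC1CCN(CCCCCN2C(=O)c3ccccc3C2=O)CC1` carries the change (a group of 11 heavy atoms (8 carbon, 1 nitrogen, 2 oxygen; one five-membered non-aromatic ring with 1 hetero atom, one six-membered aromatic ring of carbon only) in place of a hydrogen atom, on a saturated chain carbon, five bonds along the chain from an amine nitrogen in a ring). Among the compounds with values here, no measured pair shows this kind of addition, so only the step from compound 1 to compound 2 bears on it, and only loosely: it shows that building out from the ring nitrogen was tolerated and gave a large gain. A further large gain is not assumed. A modest step downward is expected for compound 3, namely the estimated step of a 2.5-fold lower number from compound 2 to compound 3 (0.40 log units; beyond the scatter), smaller than the earlier one. Compound 3 is therefore estimated at 40 nM in this assay, within 10 nM to 200 nM.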

Compound 3, inhibition constant: 20 nM
For compound 3 the middle estimate is 2.0-fold (0.30 log units) above the measured one; low and high end bracket the measured number.
By their numbers in this assay, from the lowest: compound 3; then compound 2; then compound 1.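

The step of a 5.0-fold lower number from compound 2 to compound 3 (0.70 log units; beyond the scatter) in this assay shows that a saturated chain carbon, five bonds along the chain from an amine nitrogen in a ring, accepts a group of 11 heavy atoms with one five-membered non-aromatic ring and one six-membered aromatic ring of carbon only. The earlier step, a 16-fold lower number from compound 1 to compound 2 (1.20 log units; beyond the scatter), concerned only pentyl on the ring nitrogen; the new result shows that the number can still fall when the substituent is built further out, although by a modest step rather than a large one. Nothing measured bears on what lies behind this further gain.

The compounds shown do not separate the contribution of the two carbonyl groups from that of the aromatic ring within the added group. Nor do they show how a simple amine or a carboxylic acid in its place would compare, or how the same group would fare on a longer chain.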